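The source may hold more compounds than are shown below. What is called first, only, known or untested is meant among the compounds shown, and "the series" means these compounds.

Measured in a functional assay on HepG2 cells (Homo sapiens) for cytotoxicity, read by MTT assay, with a stated time of 72 h; a higher number here means a weaker inhibitor, a lower number a stronger inhibitor:

compound 1, `COc1c(OCCCCN2CCN(C)CC2)cc(O)c2c(=O)cc(-c3ccc(C)cc3)oc12`, gives 1000 nM
compound 2, `COc1c(OCCCCN2CCN(C)CC2)cc(O)c2c(=O)cc(-c3ccc(F)cc3Br)oc12`, gives 2130 nM
compound 3, `CCN(CC)CCCOc1c(OCc2ccccc2)cc(O)c2c(=O)cc(-c3ccccc3)oc12`, gives 3010 nM

Among these three numbers compound 3 has the highest. Its gap to compound 2 is within the usual scatter of repeated measurements, so the two cannot be told apart; its gap to compound 1 is beyond the scatter, so compound 3 is the weaker inhibitor of that pair.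

Compound 4, `O=c1cc(-c2ccccc2)oc2c(OCCCCN3CCCC3)c(OCc3ccccc3)cc(O)c12`, differs from compound 3 in one place: (pyrrolidin-1-yl)methyl in place of diethylamino on a saturated chain carbon, three bonds along the chain from an oxygen on an aromatic ring. Among the measured compounds shown here, the only measured step among the three compounds, a 2.1-fold higher number from compound 1 to compound 2 (0.33 log units; beyond the scatter), concerns a different part of the shared core and says nothing about the group at the end of the chain. For the measured compounds named here, there is therefore no measured step that bears on the change from compound 3 to compound 4, and the expectation is a step no larger than the scatter, in no firm direction: a 1.0-fold lower number from compound 3 to compound 4 (0.00 log units; within the scatter). On that basis compound 4 is estimated at 3000 nM in this assay, with a range from 1200 nM to 7500 nM.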

Compound 4, half-maximal inhibitory concentration: 4660 nM
For compound 4 the middle estimate is 1.6-fold (0.19 log units) below the measured one; measured number inside the range.
By their numbers in this assay, from the lowest: compound 1; then compounds 2, 3 and 4 (each within the scatter of the next, the first and the last beyond it).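

In this assay, among the compounds shown here, the step of a 1.5-fold higher number from compound 3 to compound 4 (0.19 log units; within the scatter) is the first measured change at the end of this chain, since the earlier step concerned the aryl group on the shared core. Replacing the open diethylamino end with a five-membered pyrrolidine ring, while the chain also grows by one carbon, leaves the two compounds indistinguishable here, so this particular change does not measurably shift cytotoxicity. Nothing measured alongside these compounds accounts for this result.

Ring and chain length changed together, so 4-(diethylamino)butyl or 3-(pyrrolidin-1-yl)propyl would be needed to test each change separately, and even then a small effect of either could remain hidden in the scatter. Going by these compounds, it also remains open whether a different ring at the chain end, such as morpholine, would behave the same way.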